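The source may report more compounds than this note shows. Statements on the series, on what has been measured and on what is new or still open speak of the compounds shown alone.

Measured compounds and values:

Compound 1, `Cn1cc(-c2cnc3ccc(NS(=O)(=O)c4ccc(C(F)(F)F)cc4)nc3c2)cn1`, in a functional assay on A549 cells (Homo sapiens) for antiproliferative activity, read by MTT assay, with a stated time of 48 h (on this read-out higher numbers stand for weaker inhibition and lower numbers for stronger inhibition), gives > 50000 nM, which is a limit of the assay and not a number.
Compound 2, `Cc1ccc(S(=O)(=O)Nc2ccc3ncc(-c4cnn(C)c4)cc3n2)cc1`, gives 45500 nM in this assay.
Compound 3, `Cn1cc(-c2cnc3ccnc(NS(=O)(=O)c4ccc(C(F)(F)F)cc4)c3c2)cn1`, gives > 50000 nM in this assay, again a limit of the assay.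

Compound 2 differs from compound 1 in one place: methyl in place of trifluoromethyl on an aromatic carbon. The step that this change made is an at least 1.0-fold lower number from compound 1 to compound 2 (0.04 log units; that floor lies within the scatter); the starting value is a limit, so only a floor for the step can be given, and that floor stays within the scatter. Compound 1 and compound 3 are built from the same atoms joined differently; the difference between the two cores is not broken down here. Both of them sit at the limit of > 50000 nM in this assay, at which 2 of the 3 values shown sit.

Compound 4, `Cc1ccc(S(=O)(=O)Nc2nccc3ncc(-c4cnn(C)c4)cc23)cc1`, has not yet been measured in this assay. It differs from compound 3 by methyl in place of trifluoromethyl on an aromatic carbon, the same change as from compound 1 to compound 2, at a place described in the same words.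

For compound 4 the expected step from compound 3 is a number no higher from compound 3 to compound 4 (the limit leaves the size open), a step of about the same size as the earlier one, because an at least 1.0-fold lower number from compound 1 to compound 2 (0.04 log units; that floor lies within the scatter) showed no movement beyond the scatter. Compound 3 sits at a limit, so the expectation for compound 4 is anchored to that limit. Compound 4 is therefore expected to give about 50000 nM in this assay, with a range from 20000 nM to 120000 nM, and a real chance that only a limit is reported again.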

Compound 4, half-maximal inhibitory concentration: > 50000 nM
Compound 4: no number, only a limit; the forecaster's own chance of this, stated with the estimate: 60%; the middle value sits exactly at the limit.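

In this assay compound 4 gives > 50000 nM, which is again a limit of the assay and not a number. For the compounds shown here, compound 3 also stands at a limit, so no step from compound 3 to compound 4 can be read. The compounds shown leave open whether methyl in place of trifluoromethyl changes the value on the core of compound 3, and what real values compound 1, compound 3 and compound 4 have: the limit of > 50000 nM in this assay, at which 3 of the 4 values shown sit.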